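The source may report more compounds than this note shows. Statements on the series, on what has been measured and on what is new or still open speak of the compounds shown alone.

Working notes on the series. In a functional assay on MCF7 cells (Homo sapiens) for antiproliferative activity, read by MTT assay, with a stated time of 48 h (a higher number here means a weaker inhibitor, a lower number a stronger inhibitor), compound 1 `CC(=O)N1N=C(c2ccc3ccccc3c2)OC1c1ccccc1` gives 2.43 ug/mL, compound 2 `COc1ccc(C2OC(c3ccc4ccccc4c3)=NN2C(C)=O)cc1` gives 7.35 ug/mL and compound 3 `CC(=O)N1N=C(c2ccc3ccccc3c2)OC1c1ccc(Br)cc1` gives 5.07 ug/mL. Compound 2 stands at the high end of these three numbers. Its distance from the lowest is a 3.0-fold higher number from compound 1 to compound 2 (0.48 log units; beyond the scatter), whereas the bromo case shows a 1.4-fold lower number from compound 2 to compound 3 (0.16 log units; within the scatter).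

Compound 4 `CC(=O)N1N=C(c2ccc3ccccc3c2)OC1c1ccc(Cl)cc1` is still unmeasured. The change is chloro in place of methoxy on an aromatic carbon, para to a large group: chloro in place of methoxy on an aromatic carbon.

Going by the values given here, no chloro compound has a measurement yet, so the bromo steps are the closest guide. Bromo in place of hydrogen gave a 2.1-fold higher number from compound 1 to compound 3 (0.32 log units; beyond the scatter), and bromo in place of methoxy is the step to compound 3 at 5.07 ug/mL. A step of similar size is therefore expected in this assay, toward a lower number and probably within the scatter.

The expected change is a 1.5-fold lower number from compound 2 to compound 4 (0.19 log units; within the scatter).

Compound 4 is estimated at 4.8 ug/mL, with an expected range from 2.4 ug/mL to 9.5 ug/mL.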

Compound 4, half-maximal inhibitory concentration: 2.63 ug/mL
Compound 4: the middle estimate sits 1.8-fold (0.26 log units) above what was measured, and the stated range covers the measured number.
By their numbers in this assay, from the lowest: compounds 1, 4, 3 and 2 (each within the scatter of the next, the first and the last beyond it).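

In this assay the change from 4-methoxyphenyl to 4-chlorophenyl gives a 2.8-fold lower number from compound 2 to compound 4 (0.45 log units; beyond the scatter) and so separates from compound 2, which the bromo step to compound 3 did not do. Chloro in place of hydrogen gives a 1.1-fold higher number from compound 1 to compound 4 (0.03 log units; within the scatter) and leaves compound 4 indistinguishable from compound 1, whereas bromo in place of hydrogen moved beyond the scatter. Chloro in place of bromo gives a 1.9-fold lower number from compound 3 to compound 4 (0.29 log units; within the scatter) and so does not separate the two halogens directly, even though only compound 3 stands clear of compound 1 and only compound 4 stands clear of compound 2. Nothing at hand accounts for these differences.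

From the compounds shown here alone, whether fluoro, an amine or a carboxylic acid at this place would stay close to compound 1 remains open. So does whether the same steps hold with the substituent elsewhere on this ring.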